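The compounds below may be only part of what the source reports. "The series", "measured", "known", "first", "only" and "open" are said of these compounds alone.

Two compounds have a result in a functional assay on MGC-803 cells (Homo sapiens) for inhibition, read by MTT assay, with a stated time of 48 h (a higher number here means a weaker inhibitor, a lower number a stronger inhibitor), so far. Compound 1, `COc1cc(NCc2ccc(Cl)cc2)cc(OC)c1OC`, carries no amide at all, only a secondary amine linking the chlorobenzyl group to the trimethoxyphenyl core; in this assay compound 1 reaches only the limit of > 80000 nM, which is a limit of the measurement rather than a number. Within the data shown here, compound 2, `COc1ccc(CN(C(=O)C=C(C)C)c2cc(OC)c(OC)c(OC)c2)cc1O`, has an amide on that nitrogen and is the single compound with a real number: in this assay compound 2 gives 320 nM, so it stands alone and there is no measured step to compare it with the limit of > 80000 nM in this assay, at which 1 of the 2 values shown sits.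

Compound 3, `C=CC(=O)N(Cc1ccc(OC)c(O)c1)c1cc(OC)c(OC)c(OC)c1`, has not yet been measured. It differs from compound 2 in one place: vinyl in place of 2-methylprop-1-en-1-yl on a carbonyl carbon. The amide stays, only the substituent on its carbonyl carbon shrinks.

Among the measured compounds shown here, because no step between measured compounds exists, there is nothing to anchor the size of this change. A small step is expected, not clearly beyond the usual scatter, perhaps slightly towards a stronger inhibitor: from compound 2 to compound 3 the expected step is a 1.5-fold lower number from compound 2 to compound 3 (0.16 log units; within the scatter). Compound 3 is estimated at 220 nM in this assay, within a range from 60 nM to 800 nM.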

Compound 3, half-maximal inhibitory concentration: 62 nM
For compound 3 the middle estimate is 3.5-fold (0.55 log units) above the measured one; the measured number falls inside the stated range.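

Among these compounds, this is the first measured step, and it shows that the group on a carbonyl carbon whose other neighbour is the amide-type nitrogen is a place where a small edit matters: in this assay the change from 2-methylprop-1-en-1-yl to vinyl gives a 5.2-fold lower number from compound 2 to compound 3 (0.71 log units; beyond the scatter) and so moves the number by more than repeat measurements would. The direction is also informative, as the smaller vinyl group, with 2 heavy atoms in place of 4, goes with the stronger inhibitor, although a single pair gives a direction at this one position and not a general trend. None of the measurements shown bears on the reason for this step.

Still open, on these data alone, is how far this position can be pushed, for instance whether a longer chain, a phenyl ring, an amine or a carboxylic acid on the same carbonyl carbon would keep, improve or lose the activity of compound 3. Also open, as far as these compounds go, is whether the same change would have a step of similar size if the groups elsewhere on the shared core were different.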